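This account rests on a few compounds, and the source may have more. Where it says the series, first, only, none or still open, it means among the compounds named here.

Within the data shown here, compound 2 `N#Cc1cccc(COc2ccc(CCC(=O)O)cc2)c1` is the weaker of the two compounds measured so far in a functional assay on 1321-N1 cells for agonist activity at Free fatty acid receptor 1 (Homo sapiens), read by calcium flux; a lower number here means that less compound is needed, a higher number that more compound is needed for the effect: compound 2 gives 525 nM, whereas compound 1 `O=C(O)CCc1ccc(OCc2cccc(Br)c2)cc1` gives 89.1 nM. Among the measured compounds shown here, the only step measured between them, a 5.9-fold higher number from compound 1 to compound 2 (0.77 log units; beyond the scatter), shows that exchanging the bromo for the cyano costs activity by a modest but real margin. Compound 3 `O=C(O)CCc1ccc(OCc2cccc(C(F)(F)F)c2)cc1` carries the change (trifluoromethyl in place of cyano on an aromatic carbon). For the measured compounds named here, no measured step concerns a trifluoromethyl directly; the only step that bears on this position is the one from compound 1 to compound 2, in which a halogen was replaced by the cyano and the number rose. Reversing that direction, a trifluoromethyl in place of the cyano is expected to bring the number back down toward that of compound 1, so that for compound 3 the step of a 3.5-fold lower number from compound 2 to compound 3 (0.54 log units; beyond the scatter) is expected. The estimate for compound 3 in this assay is therefore 150 nM, with a range from 50 nM to 500 nM.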

Compound 3, half-maximal effective concentration: 83.2 nM
For compound 3 the middle estimate is 1.8-fold (0.26 log units) above the measured one, within the range that was stated.
By their numbers in this assay, from the lowest: compounds 3 and 1 (each within the scatter of the next); then compound 2.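

In this assay, the loss seen with the cyano does not extend to every replacement of the bromo at this position: a 6.3-fold lower number from compound 2 to compound 3 (0.80 log units; beyond the scatter) takes the number back to the level of the bromo compound, and a 1.1-fold lower number from compound 1 to compound 3 (0.03 log units; within the scatter) leaves trifluoromethyl and bromo indistinguishable here. Among these three groups on the aromatic carbon, the cyano alone stands apart, while the other two give equivalent numbers despite being different groups. From the compounds shown here alone, whether a chloro, a methoxy or an amine at this place would match bromo and trifluoromethyl or fall with the cyano remains open, as does whether this order of groups would hold elsewhere on the shared core. Nothing available explains why the cyano separates from the other two groups.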